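Aryl amide variation on a bicyclic caspase-8 inhibitor series

This account rests on a few compounds, and the source may have more. Where it says the series, first, only, none or still open, it means among the compounds named here.

Of the compounds shown here, three on a shared core have been measured in an assay on isolated protein for inhibition of Caspase-8 (Homo sapiens); on this read-out lower numbers stand for stronger inhibition and higher numbers for weaker inhibition. Compound 1 `O=C1C[C@H](NC(=O)[C@@H]2COC[C@@H]3CCCC[C@H](NC(=O)c4nccc5ccccc45)C(=O)N32)C(O)O1` gives 264 nM in this assay, the second highest of the three numbers. Compound 2 `O=C1C[C@H](NC(=O)[C@@H]2CN(C(=O)OCc3ccccc3)C[C@@H]3C/C=C\C[C@H](NC(=O)c4ccccc4)C(=O)N32)C(O)O1` gives 13 nM, a number beyond the scatter below that of compound 1, while compound 3 `O=C1C[C@H](NC(=O)[C@@H]2COC[C@@H]3C/C=C\C[C@H](NC(=O)c4ccc(C(F)(F)F)cc4)C(=O)N32)C(O)O1` gives 6450 nM, beyond the scatter above compound 1. For the measured compounds named here, compounds 2 and 3 differ from compound 1 in more than one place, so no single-change step between measured compounds is available; the spread of the three values only shows that the aryl amide and the core ring substitution together move the read-out across a wide span.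

Compound 4 `O=C1C[C@H](NC(=O)[C@@H]2COC[C@@H]3CCCC[C@H](NC(=O)c4cc5ccccc5s4)C(=O)N32)C(O)O1` is the next single step from compound 1: 1-benzothiophen-2-yl in place of isoquinolin-1-yl on a carbonyl carbon. What leaves and what enters are both bicyclic aromatic groups of similar size, each with one hydrogen-bond acceptor and no donor, so no step beyond the usual scatter in this assay is expected with confidence in either direction, with a slight lean toward a weaker number. The step from compound 1 is estimated as a 1.5-fold higher number from compound 1 to compound 4 (0.18 log units; within the scatter). Compound 4 is accordingly expected to give about 400 nM in this assay, within a range of 100 nM to 1600 nM.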

Compound 4, half-maximal inhibitory concentration: 429 nM
Estimate against measurement, compound 4: 1.1-fold (0.03 log units) below; the measured number falls inside the stated range.
By their numbers in this assay, from the lowest: compound 2; then compounds 1 and 4 (each within the scatter of the next); then compound 3.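

Notes on the series: the first single-change step sits at the aryl group on a carbonyl carbon whose other neighbour is an amide-type nitrogen, and in this assay 1-benzothiophen-2-yl in place of isoquinolin-1-yl gives a 1.6-fold higher number from compound 1 to compound 4 (0.21 log units; within the scatter). On the core of compound 1, this position therefore accepts a swap of the six-membered aromatic ring with one hetero atom, carrying nitrogen, for a five-membered aromatic ring with one hetero atom, carrying sulfur, without a step beyond the scatter, and the pair cannot be told apart on this read-out. No measured information on either group is available to account for this result.

Going by these compounds, the wide gaps to compound 2 and compound 3 remain unassigned, since each differs from compound 1 in more than one place, and it is open whether the same exchange would give a similar step on either of their cores. Also open, on these data alone, is how a cyclohexyl group, or a bicyclic aromatic group carrying a carboxylic acid or an amine, would read at this carbonyl carbon in this assay.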